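The compounds below may be only part of what the source reports. "The series", "measured", "known", "first", "only" and "open" are said of these compounds alone.

The measured compounds so far:
compound 1, `CC(C)N(C(=O)CN1C=CN(c2ccccc2)C(=O)C(Cc2n[nH]c3ccccc23)C1=O)c1ccc(F)cc1`, which in a functional assay on CHO cells for agonist activity at Melanocyte-stimulating hormone receptor (Homo sapiens), read by a luciferase reporter, with a stated time of 4 h (a higher number here means that more compound is needed for the effect, a lower number that less compound is needed), gives 50.1 nM
compound 2, `COc1ccc(N(C(=O)CN2C=CN(c3ccccc3)C(=O)C(Cc3n[nH]c4ccccc34)C2=O)C(C)C)cc1`, which in this assay gives 29.5 nM

Going by the values given here, compound 2 holds the lowest of these two numbers, but its only neighbour, compound 1, sits close: a 1.7-fold lower number from compound 1 to compound 2 (0.23 log units; within the scatter), so the two cannot be told apart on these data. Compound 3, `COc1ccc(N(C(=O)CN2C=CN(c3cccnc3)C(=O)C(Cc3n[nH]c4ccccc34)C2=O)C(C)C)cc1`, has not yet been measured in this assay. Its change relative to compound 2 is pyridin-3-yl in place of phenyl on an amide-type nitrogen in a ring. Among the compounds with values here, the single measured step concerns a different part of the shared core and was itself within the scatter, so it gives no guide to this exchange of one aromatic ring for another on the ring nitrogen. Within the data shown here, with no measured step bearing on the change, the expectation rests on compound 2 alone, and the estimated step of a 1.1-fold higher number from compound 2 to compound 3 (0.04 log units; within the scatter) is expected to be no larger than the scatter, in either direction. Compound 3 is therefore expected to give 32 nM, with a range from 10 nM to 100 nM.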

Compound 3, half-maximal effective concentration: 178 nM
Estimate against measurement, compound 3: 5.6-fold (0.75 log units) below; measured number outside the range, above it.
By their numbers in this assay, from the lowest: compounds 2 and 1 (each within the scatter of the next); then compound 3.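

Going by these compounds alone, the aromatic ring on the amide-type nitrogen is not a neutral place in the molecule: in this assay the exchange of phenyl for pyridin-3-yl gives a 6.0-fold higher number from compound 2 to compound 3 (0.78 log units; beyond the scatter), the only step so far that lies beyond the scatter. The two rings have the same count of heavy atoms and differ by one ring carbon replaced with nitrogen, which adds one hydrogen-bond acceptor, so a very small change in atoms is enough here to shift the number clearly, unlike the exchange of fluoro for methoxy on the other aromatic ring. Nothing available explains why this exchange raises the number.

A pyridin-2-yl or pyridin-4-yl group on the same nitrogen would show whether the step depends on where the nitrogen stands in the ring or appears with any of the pyridine rings. On these data alone, it also remains open whether the same exchange would give a step of similar size with the fluoro group of compound 1, and how a phenyl ring carrying an amine or a carboxylic acid would behave at this position.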